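The source may report more compounds than this note shows. Statements on the series, on what has been measured and on what is new or still open speak of the compounds shown alone.

Working notes on the series. In an assay on V79 cells for inhibition of cytochrome P450 11B1, mitochondrial (Homo sapiens), read by HTRF, with a stated time of 1 h (on this read-out lower numbers stand for stronger inhibition and higher numbers for weaker inhibition), compound 1 `Cn1c(-c2cccnc2)nc2ccc(F)cc21` gives 677 nM. Compound 2 `Cc1ccncc1-c1nc2cc(F)c(F)cc2n1C1CC1` gives 723 nM in this assay, and the two numbers sit within the scatter of each other, so compound 1 and compound 2 cannot be told apart on these data. Within the data shown here, compound 2 differs from compound 1 in more than one place, so no single step between measured compounds is available.

Compound 3 `Fc1ccc2nc(-c3cccnc3)n(C3CCC3)c2c1` is not yet measured in this assay. It differs from compound 1 in one place: cyclobutyl in place of methyl on an aromatic nitrogen. The measured pair gives no direct reading on a change of this kind, and the change adds no hydrogen-bond donor or acceptor and no net charge.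

Expectation: no step beyond the scatter from compound 1 to compound 3 in this assay; a small move toward a lower number is estimated, a 1.4-fold lower number from compound 1 to compound 3 (0.13 log units; within the scatter), but it stays inside the scatter. The estimate for compound 3 in this assay is 500 nM, with a range from 150 nM to 1600 nM.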

Compound 3, half-maximal inhibitory concentration: > 10000 nM
Compound 3: no number, only a limit; the forecaster's own chance of this, stated with the estimate: 3%; middle value at least 20-fold (1.30 log units) away from the limit.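

Working notes, continued. In this assay, among these compounds, the exchange of methyl for cyclobutyl on an aromatic nitrogen gives an at least 14-fold higher number from compound 1 to compound 3 (1.16 log units; beyond the scatter), the first reading on this position, and it shows that the read-out is highly sensitive to the group placed here. The reading of > 10000 nM for compound 3 is a limit of the assay and not a number: the limit of > 10000 nM in this assay, at which 1 of the 3 values shown sits. The change adds carbon atoms and a four-membered ring but no hydrogen-bond donor or acceptor and no net charge, so on this single pair a large step arises on this nitrogen with no change in those counts.

Going by these compounds, the true size of the step stays open, since the limit gives only its lower bound, and one pair cannot show whether the ring or the number of carbon atoms carries it. Also open, on these data alone, is where an ethyl or isopropyl group on this nitrogen would fall, and whether a chain ending in an amine or a carboxylic acid would stay near compound 1 or move as far as cyclobutyl does.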